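Series notes: growth inhibition of compounds 1 to 3

The source may report more compounds than this note shows. Statements on the series, on what has been measured and on what is new or still open speak of the compounds shown alone.

Compound 1 `COc1cc(/C=C/C(=O)/C=C/c2ccccc2)ccc1OCc1cn(CCCOc2cc(=O)oc3ccccc23)nn1` is the reference point of the pair measured so far. In a functional assay on THP-1 cells (Homo sapiens) for inhibition, read by sulforhodamine B assay, with a stated time of 48 h, tested at 50 uM (a higher number here means more inhibition of growth at the concentration tested, a lower number less inhibition of growth), compound 1 gives 48%, the higher of the two numbers in hand. Among the compounds with values here, compound 2 `COc1cc(/C=C/C(=O)/C=C/c2ccccc2)ccc1OCc1cn(CCCCOc2cc(=O)oc3ccccc23)nn1` is a close relative of compound 1; in this assay compound 2 gives 36%, and compound 2 thus sits below compound 1 by a gap beyond the usual scatter, though no single-point step between the two has been worked out, so only the two values themselves speak.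

Compound 3 `COc1ccc(/C=C/C(=O)/C=C/c2ccc(OCc3cn(CCCOc4cc(=O)oc5ccccc45)nn3)c(OC)c2)cc1` has not yet been run in this assay. Relative to compound 1 it differs by methoxy in place of hydrogen on an aromatic carbon. Within the data shown here, nothing measured so far probes a change of this kind, so no step of known size can be carried over. The expectation for compound 3 is no change at the digits printed from compound 1 to compound 3 (within the scatter), no more than the scatter in either direction. Compound 3 is therefore estimated at 48% in this assay, within a range from 30% to 66%.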

Compound 3, percent growth inhibition at one concentration: 56%
Compound 3: middle estimate off by 8 percentage points, on the low side, and the stated range covers the measured number.
By their numbers in this assay, from the lowest: compound 2; then compounds 1 and 3 (each within the scatter of the next).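

Within the data shown here, the phenyl ring at the far end of the 2-phenylethenyl arm is unsubstituted in both compounds 1 and 2, so this is the first look at a substituent on that ring. In this assay the change of phenyl to 4-methoxyphenyl gives a number 8 percentage points higher from compound 1 to compound 3 (within the scatter) and so leaves compounds 1 and 3 indistinguishable: this aromatic carbon, para to a large group, accepts methoxy in place of hydrogen without a loss of growth inhibition beyond the scatter, and no gain can be claimed either. No measurement in hand speaks to the reason for this outcome.

Going by these compounds, a single substituent at a single place says little about the scope of this position, so what a hydroxy group, an amine, a carboxylic acid or a longer alkoxy chain on the same aromatic carbon would do remains open. Also open, on these data alone, is whether 4-methoxyphenyl behaves the same way when joined to the longer chain of compound 2, and whether a read-out at one concentration would hold up across a full concentration series.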